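The source may report more compounds than this note shows. Statements on the series, on what has been measured and on what is new or still open speak of the compounds shown alone.

Working notes on the series. Compound 2 `O=C1C=C(NC2CCCCC2)C(=O)c2c1nc1n2[C@H]2OC[C@@H](O)[C@H]2OC1` carries a cyclohexylamino group on the shared core. In a functional assay on ECa-109 cells for inhibition, with ECa-109 cell line (Homo sapiens) as the target, read by sulforhodamine B assay (on this read-out higher numbers stand for weaker inhibition and lower numbers for stronger inhibition), compound 2 gives only a limit, > 16000 nM. Compound 1 `CCc1ccc(NC2=CC(=O)c3c(nc4n3[C@H]3OC[C@@H](O)[C@H]3OC4)C2=O)cc1` carries an anilino group bearing ethyl on an aromatic carbon; in this assay compound 1 likewise gives only a limit, > 4000 nM. Compound 3 `O=C1C(Nc2ccc(C(F)(F)F)cc2)=CC(=O)c2c1nc1n2[C@H]2OC[C@@H](O)[C@H]2OC1`, with trifluoromethyl in place of ethyl, gives 2250 nM in this assay. Going by the values given here, the one measured step, an at least 1.7-fold lower number from compound 1 to compound 3 (0.24 log units; that floor lies within the scatter), concerns the substituent on the aniline ring, and its size rests on (the limit of > 4000 nM in this assay, at which 1 of the 3 values shown sits); it says nothing about the ring attached to the amine nitrogen.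

Compound 4 `O=C1C=C(Nc2ccccc2)C(=O)c2c1nc1n2[C@H]2OC[C@@H](O)[C@H]2OC1` is the unmeasured member; it differs from compound 2 by phenyl in place of cyclohexyl on an amine nitrogen. Among the compounds with values here, no measured step covers this change. What the numbers show is that compound 2 sits at the limit of > 16000 nM in this assay, at which 1 of the 3 values shown sits, compound 1 sits at the limit of > 4000 nM in this assay, at which 1 of the 3 values shown sits, and compound 3 gives a number. Compound 4 is expected to move toward the anilino members, a step of an at least 3.2-fold lower number from compound 2 to compound 4 (0.50 log units; beyond the scatter). The estimate for compound 4 in this assay is 5000 nM, from 1500 nM to 16000 nM, with a real chance that only a limit is returned.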

Compound 4, half-maximal inhibitory concentration: 4970 nM
For compound 4 the middle estimate is 1.0-fold (0.00 log units) above the measured one; the range from low to high includes it.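

In this assay, going by these compounds alone, the change from cyclohexylamino to anilino gives the first measured step at the ring on the amine nitrogen, where the earlier step concerned only the substituent on the aniline ring: an at least 3.2-fold lower number from compound 2 to compound 4 (0.50 log units; beyond the scatter). The anilino group with no substituent on the aromatic ring also returns a number, with compound 4 at 4970 nM. Both groups count the same heavy atoms, so the step compares a six-membered non-aromatic ring of carbon with a six-membered aromatic one, and its size is only a floor: the limit of > 16000 nM in this assay, at which 1 of the 4 values shown sits.

Compound 1 gives only a limit, > 4000 nM, and the step between compound 4 and compound 1 cannot be read. Still open, from the compounds shown here alone, is how an amine or a carboxylic acid on the aniline ring, or a longer chain on the amine nitrogen in place of the ring, would read.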